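Trifluoromethyl for chloro on the shared core

A few compounds are considered here, and "the series" means these few. Any claim that something is new, unique, unknown or untested is made for them only; others in the source may bear on it.

Compound 1 `Clc1ccc2c(NCCCN3CCN(c4ccccc4)CC3)ccnc2c1` carries a chloro on the shared core and an amine-linked chain ending in a phenylpiperazine. Compound 2 `O=C1C(=O)N(CCCNc2ccnc3cc(Cl)ccc23)c2cc(Br)ccc21` keeps the same chloro-bearing core and the same linking chain but ends in a different terminal group. In a functional assay on MCF7 cells (Homo sapiens) for antiproliferative activity, read by sulforhodamine B assay, with a stated time of 48 h (a higher number here means a weaker inhibitor of growth, a lower number a stronger inhibitor of growth), compound 1 gives 12800 nM. Compound 2 gives 16600 nM in this assay. The two numbers lie within the scatter of each other, so no order between compound 1 and compound 2 can be read from them. Within the data shown here, no step between measured compounds is available that would show how a change on the core moves this assay.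

Compound 3 `FC(F)(F)c1ccc2c(NCCCN3CCN(c4ccccc4)CC3)ccnc2c1` differs from compound 1 by trifluoromethyl in place of chloro on an aromatic carbon. Among the measured compounds shown here, with no measured step of this kind, the expected step of a 1.2-fold lower number from compound 1 to compound 3 (0.07 log units; within the scatter) is one that stays within the scatter, in no firm direction. Compound 3 is therefore expected to give about 11000 nM in this assay. Its expected range runs from 4500 nM to 27000 nM.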

Compound 3, concentration for 50% growth inhibition: 8750 nM
For compound 3 the middle estimate is 1.3-fold (0.10 log units) above the measured one; low and high end bracket the measured number.
By their numbers in this assay, from the lowest: compounds 3, 1 and 2 (each within the scatter of the next).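

Among these compounds, the step of a 1.5-fold lower number from compound 1 to compound 3 (0.17 log units; within the scatter) in this assay is the first measured one at this position, and it gives trifluoromethyl in place of chloro on an aromatic carbon a reading of its own, with the linking chain and terminal phenylpiperazine held fixed. This exchange stays within the scatter, so neither group can be placed ahead of the other here, and the position tolerates either group without a firm change in growth inhibition. Nothing at hand explains this result.

On these data alone, whether a nitrile, a methoxy group or an amine at this position would move the number beyond the scatter remains open. Also open, as far as these compounds go, is whether the same exchange reads alike with the terminal group of compound 2 or with a longer chain.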